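The source may report more compounds than this note shows. Statements on the series, on what has been measured and on what is new or still open speak of the compounds shown alone.

Measured compounds:
Compound 1 `CCN(CC)S(=O)(=O)c1ccc(S(=O)(=O)N2CCC[C@@H](C(=O)NC3COC3)C2)cc1` gives 13800 nM in a functional assay on BXPC-3 cells (Homo sapiens) for inhibition, read by MTT assay, with a stated time of 7 days; a lower number here means a stronger inhibitor, a higher number a weaker inhibitor.
Compound 2 `O=C([C@@H]1CCCN(S(=O)(=O)c2ccc(S(=O)(=O)N3CC[C@H](O)C3)cc2)C1)N1CCC(F)(F)CC1` gives 580 nM in this assay.
Compound 3 `CC(C)S(=O)(=O)c1ccc(S(=O)(=O)N2CCC[C@@H](C(=O)N3CCC(F)(F)CC3)C2)cc1` gives 50 nM in this assay.

Compound 1 stands at the highest number of the three, so it is the weakest inhibitor here; compound 2 is the nearest to it and compound 3 the furthest, both beyond the scatter. Compound 4 `CCN(CC)S(=O)(=O)c1ccc(S(=O)(=O)N2CCC[C@@H](C(=O)N[C@H]3CC[C@@H](OC)CC3)C2)cc1` has not yet been measured. It differs from compound 1 in one place: 4-methoxycyclohexyl in place of oxetan-3-yl on an amide-type nitrogen. Among the compounds with values here, the only step measured so far, a 12-fold lower number from compound 2 to compound 3 (1.06 log units; beyond the scatter), concerns a group on a sulfonyl sulfur, not the amide-type nitrogen, so it does not bear directly on this change. Compounds 2 and 3 carry a different amide group than compound 1 and show lower numbers, but they also differ from compound 1 elsewhere, so no clean comparison exists. On that thin basis a moderately lower number is expected for compound 4, within the step of a 3.5-fold lower number from compound 1 to compound 4 (0.54 log units; beyond the scatter), giving an estimate of 4000 nM with a range from 800 nM to 20000 nM.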

Compound 4, half-maximal inhibitory concentration: 2150 nM
Compound 4: the middle estimate sits 1.9-fold (0.27 log units) above what was measured; the range from low to high includes it.
By their numbers in this assay, from the lowest: compound 3; then compound 2; then compound 4; then compound 1.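

Replacing oxetan-3-yl with 4-methoxycyclohexyl on the amide-type nitrogen gives a 6.4-fold lower number from compound 1 to compound 4 (0.81 log units; beyond the scatter) in this assay, the first clean sign that the group at this position affects the read-out. The entering group has 8 heavy atoms against 4, and a six-membered carbon ring in place of a four-membered ring, while the counts of hydrogen-bond donors and acceptors stay the same, so a change in those counts cannot describe this step. No measurement shown here explains why the number falls.

Going by these compounds, it remains open whether the ring, its size or the methoxy group accounts for the step; a plain cyclohexyl or a 4-aminocyclohexyl group at this nitrogen would help separate these. On these data alone, it is also open whether the step would hold with a different group on the other sulfonyl sulfur.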